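Aryl for Furan on the Core of Compound 2

The source may report more compounds than this note shows. Statements on the series, on what has been measured and on what is new or still open speak of the compounds shown alone.

Of the compounds shown here, three have been measured in a functional assay on CHO-K1 cells for antagonist activity at adenosine receptor A1 (Homo sapiens), read by a beta-galactosidase reporter and cAMP accumulation, with stated times of 15 min and 6 h; on this read-out lower numbers stand for stronger inhibition and higher numbers for weaker inhibition. Compound 1 `Cc1ccc(-c2nc(N)c3ccsc3n2)o1` gives 493 nM, compound 2 `Nc1nc(-c2ccc(C3CC3)o2)nc2sc(Cc3ccccc3)cc12` gives 861 nM, and compound 3 `Nc1nc(-c2ccccc2)nc2sc(-c3ccccc3)cc12` gives 237 nM. Compound 2 carries the highest of the three numbers, though its gap to compound 1 lies within the scatter and only its gap to compound 3 lies beyond it. Compound 4 `COc1cccc(-c2nc(N)c3cc(Cc4ccccc4)sc3n2)c1` is unmeasured. It differs from compound 2 in one place: 3-methoxyphenyl in place of 5-cyclopropylfuran-2-yl on an aromatic carbon. For the measured compounds named here, no pair of measured compounds isolates this change, so the expectation rests on the spread of the three numbers. A modest step toward a lower number is expected, a 2.2-fold lower number from compound 2 to compound 4 (0.33 log units; beyond the scatter), not certain to exceed the scatter. Compound 4 is estimated at 400 nM, within a range from 120 nM to 1300 nM in this assay.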

Compound 4, inhibition constant: 266 nM
For compound 4 the middle estimate is 1.5-fold (0.18 log units) above the measured one; measured number inside the range.
By their numbers in this assay, from the lowest: compounds 3, 4, 1 and 2 (each within the scatter of the next, the first and the last beyond it).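

In this assay, for the compounds shown here, 3-methoxyphenyl in place of 5-cyclopropylfuran-2-yl on the carbon between two ring nitrogen atoms gives a 3.2-fold lower number from compound 2 to compound 4 (0.51 log units; beyond the scatter) and provides the first single-place comparison in this set. At this position, a six-membered aromatic ring of carbon only can therefore replace the five-membered aromatic ring without raising the number, while the heavy-atom and hydrogen-bond acceptor counts stay the same. No measurement here explains the step.

This one pair cannot separate the change of ring from the presence of the methoxy group. From the compounds shown here alone, how a pyridine ring or a morpholine at this carbon would read remains open.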